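From piperidin-1-yl to dimethylamino on a carbonyl

The source may hold more compounds than are shown below. What is called first, only, known or untested is meant among the compounds shown, and "the series" means these compounds.

Compound 1 `CNC(=O)CN1CCC(c2cc3c(-c4ccc(=O)n(C(C)C)c4)ccnc3[nH]2)CC1` gives 2.6 L/kg
Compound 2 `COc1cc(F)ccc1-c1ccnc2[nH]c(C3CCN(CC(=O)N(C)C)CC3)cc12` gives 2.3 L/kg
Compound 3 `CC(C)n1cc(-c2ccnc3[nH]c(C4CCN(CC(=O)N5CCCCC5)CC4)cc23)ccc1=O` gives 8.1 L/kg

In an ADME assay (Rattus norvegicus, strain Han-wistar) for pharmacokinetics, at a dose of 1.5 umol/kg by the intravenous route (a higher number here means that more of the compound sits outside the plasma, a lower number that more of the compound stays in the plasma), compound 3 has the highest of the three numbers, and its gaps to compound 1 and compound 2 both lie beyond the scatter. Compound 4 `CC(C)n1cc(-c2ccnc3[nH]c(C4CCN(CC(=O)N(C)C)CC4)cc23)ccc1=O` has not yet been measured and differs from compound 3 at one place, on a carbonyl carbon whose other neighbour is a saturated chain carbon: dimethylamino in place of piperidin-1-yl on a carbonyl carbon. In words, dimethylamino takes the place of piperidin-1-yl.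

For the measured compounds named here, one measured step bears directly on this change: a 3.1-fold higher number from compound 1 to compound 3 (0.49 log units; beyond the scatter). There, piperidin-1-yl replaced methylamino on the same carbonyl, a modest step that still lies beyond the scatter. Compound 4 moves the opposite way, from piperidin-1-yl back to a group with no ring, so most of that step may be reversed. Compound 2 also carries dimethylamino on the carbonyl and gives 2.3 L/kg, but the rest of compound 2 differs from compound 3, so its support is only partial.

A lower number is therefore expected in this assay, and the estimated change is a 2.7-fold lower number from compound 3 to compound 4 (0.43 log units; beyond the scatter). The estimate for compound 4 is 3 L/kg, with an expected range from 1.6 L/kg to 5.5 L/kg.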

Compound 4, volume of distribution in the Rattus norvegicus assay: 5.9 L/kg
Beside the measured number, compound 4's estimate is 2.0-fold (0.29 log units) below it, and the stated range ends below it.
By their numbers in the Rattus norvegicus assay, from the lowest: compounds 2 and 1 (each within the scatter of the next); then compounds 4 and 3 (each within the scatter of the next).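

In the Rattus norvegicus assay, the loss of the ring from this carbonyl carbon leaves no clear mark (a 1.4-fold lower number from compound 3 to compound 4 (0.14 log units; within the scatter)), whereas the step that puts methyl in place of the amide hydrogen is larger (a 2.3-fold higher number from compound 1 to compound 4 (0.36 log units; beyond the scatter)), so among compounds 1, 3 and 4 the line falls between the amide that keeps its hydrogen and the two that do not. The same change from piperidin-1-yl to dimethylamino does register in a physicochemical assay for lipophilicity, using the shake flask method, measured as octanol-water partition, at pH 7.4; on this read-out lower numbers stand for lower lipophilicity and higher numbers for higher lipophilicity (compound 3 gives 2.8 and compound 4 gives 1.9), so a clear shift in that read-out came here without a clear shift in how far the compound spreads outside the plasma: the measured distribution coefficient of compound 3, 2.8, and of compound 4, 1.9, a number 0.90 log units lower (beyond the scatter) With dimethylamino held fixed on the carbonyl, the group on the aromatic carbon also matters in the Rattus norvegicus assay (a 2.6-fold higher number from compound 2 to compound 4 (0.41 log units; beyond the scatter)).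

From the compounds shown here alone, it remains open whether morpholin-4-yl or pyrrolidin-1-yl on the same carbonyl carbon would sit with compounds 3 and 4, and whether an unsubstituted amide would sit with compound 1. A carboxylic acid in place of the amide could show how far this end of the molecule can move the volume of distribution at all.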